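This account rests on a few compounds, and the source may have more. Where it says the series, first, only, none or still open, it means among the compounds named here.

Measured in a functional assay on A549 cells (Homo sapiens) for cytotoxicity, read by MTT assay, with a stated time of 72 h; on this read-out lower numbers stand for stronger inhibition and higher numbers for weaker inhibition:
compound 1 `COc1cc2c(Oc3ccc(NC(=O)c4cn(-c5cc(C)ccc5C)cn4)cc3F)ccnc2cc1OCCCN1CCN(C)CC1` gives 350 nM
compound 2 `COc1cc2c(Oc3ccc(NC(=O)c4cn(-c5cc(C)ccc5C)cn4)cc3F)ccnc2cc1OCCCN1CCCCC1` gives 510 nM
compound 3 `COc1cc2c(Oc3ccc(NC(=O)/C=C/S(=O)(=O)c4ccccc4OC)cc3F)ccnc2cc1OCCCN1CCN(C)CC1` gives 320 nM

Compound 1 and compound 2 share one core and differ by piperidin-1-yl in place of 4-methylpiperazin-1-yl on a saturated chain carbon, three bonds along the chain from an oxygen on an aromatic ring. The step in this assay is a 1.5-fold higher number from compound 1 to compound 2 (0.16 log units; within the scatter). Compound 3 carries a different core; how the core of compound 3 differs from the core of compound 1 is not broken down here. In this assay the numbers of compound 3 and compound 1 lie within the scatter of each other.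

Compound 4 `COc1cc2c(Oc3ccc(NC(=O)/C=C/S(=O)(=O)c4ccccc4OC)cc3F)ccnc2cc1OCCCN1CCCCC1` is not yet measured. It differs from compound 3 by piperidin-1-yl in place of 4-methylpiperazin-1-yl on a saturated chain carbon, three bonds along the chain from an oxygen on an aromatic ring, the same change, in the same place, as from compound 1 to compound 2. In this assay, within the data shown here, the step from compound 3 to compound 4 is expected to be a 1.5-fold higher number from compound 3 to compound 4 (0.18 log units; within the scatter), because the one measured instance of this change is a 1.5-fold higher number from compound 1 to compound 2 (0.16 log units; within the scatter). Compound 4 is estimated at 480 nM, expected between 250 nM and 950 nM.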

Compound 4, half-maximal inhibitory concentration: 470 nM
Compound 4: middle estimate off by 1.0-fold (0.01 log units), on the high side; measured number inside the range.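

In this assay, piperidin-1-yl in place of 4-methylpiperazin-1-yl gives a 1.5-fold higher number from compound 3 to compound 4 (0.17 log units; within the scatter) on the second core. Neither this step nor the earlier one lies beyond the scatter, so the pair does not show that the change itself alters the read-out, and two cores do not establish how it would behave on any further core. What can be said is that the change carries from one core to the other with no detectable difference between the steps: the same change on two cores in this assay, a 1.5-fold higher number (0.16 log units; within the scatter) from compound 1 to compound 2 and a 1.5-fold higher number (0.17 log units; within the scatter) from compound 3 to compound 4, 1.0-fold (0.00 log units) apart, within the scatter of two such steps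

Open, going by these compounds, are other amines at the end of the chain, such as morpholin-4-yl or dimethylamino, in place of 4-methylpiperazin-1-yl and piperidin-1-yl. Also open, on these data alone, are shorter or longer chains than 3-(piperidin-1-yl)propyl.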